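The source may report more compounds than this note shows. Statements on the series, on what has been measured and on what is new or still open speak of the compounds shown alone.

Measured in a functional assay on HepG2 cells (Homo sapiens) for antiproliferative activity, read by MTT assay, with a stated time of 3 days; a lower number here means a stronger inhibitor, a higher number a weaker inhibitor:
- Compound 1 `O=C1c2ccccc2C(=O)N1C/C=C\Cn1cc(C#Cc2ccc(Br)cc2)c(=O)[nH]c1=O`: 89000 nM
- Compound 2 `CCCCCC#Cc1cn(C/C=C/CN2C(=O)c3ccccc3C2=O)c(=O)[nH]c1=O`: 9000 nM

Compound 1 has the higher of the two numbers, and its gap to compound 2 lies beyond the scatter. The unmeasured compound 3 `CCCCC#Cc1cn(C/C=C\CN2C(=O)c3ccccc3C2=O)c(=O)[nH]c1=O` differs from compound 1 in one place: butyl in place of 4-bromophenyl on a triple-bonded carbon. This puts butyl in place of 4-bromophenyl on a triple-bonded carbon. Within the data shown here, no measured pair shows this change, so its size cannot be read directly from the data. Among the measured compounds shown here, the only guide is that compound 1 gives 89000 nM while compound 2 gives 9000 nM. A moderate step downward in this assay, beyond the scatter, is therefore expected, though it may stop short of the gap between those two. The estimated change is a 3.6-fold lower number from compound 1 to compound 3 (0.55 log units; beyond the scatter). The expected value for compound 3 is 25000 nM, with an estimated range of 7000 nM to 80000 nM.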

Compound 3, half-maximal inhibitory concentration: 17000 nM
Beside the measured number, compound 3's estimate is 1.5-fold (0.17 log units) above it; low and high end bracket the measured number.
By their numbers in this assay, from the lowest: compounds 2 and 3 (each within the scatter of the next); then compound 1.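

In this assay, butyl in place of 4-bromophenyl on a triple-bonded carbon gives a 5.2-fold lower number from compound 1 to compound 3 (0.72 log units; beyond the scatter), the only direct reading of this change among the compounds shown, since compound 1 and compound 2 differ in more than one place. At this position, then, an aromatic ring carrying bromine is not required for activity in this assay: compound 3, with an open butyl chain, gives 17000 nM. Nothing available explains the size of this step.

The compounds shown leave open whether the step follows the loss of the bromine or the loss of the ring, which an unsubstituted phenyl at this position could separate. As far as these compounds go, how far the chain can change also remains open, for instance with a longer chain such as octyl or with a chain ending in an amine.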